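The source may hold more compounds than are shown below. What is called first, only, known or untested is meant among the compounds shown, and "the series" means these compounds.

Values measured so far in an ADME assay on BJ cells (Homo sapiens) for cytotoxicity, with a stated time of 72 h (on this read-out lower numbers stand for an effect already at smaller amounts and higher numbers for an effect only at larger amounts of compound), for the series:

- compound 1 `Cc1cc(NC(=O)Nc2ccc(F)cc2)c2ccccc2n1` gives > 25000 nM (a limit)
- compound 2 `COC(=O)c1ccc(NC(=O)Nc2cc(C)nc3ccccc23)cc1` gives 21000 nM (a number)
- compound 3 `Cc1cc(NC(=O)Nc2cccnc2)c2ccccc2n1` gives > 25000 nM (a limit)

Compound 3 reports only a limit, namely the limit of > 25000 nM in this assay, at which 2 of the 3 values shown sit, and so offers no number to start a step from. Compound 4 `Cc1cc(NC(=O)Nc2ccc(N)cc2)c2ccccc2n1` differs from compound 3 by 4-aminophenyl in place of pyridin-3-yl on an amide-type nitrogen in a single change: 4-aminophenyl in place of pyridin-3-yl on an amide-type nitrogen.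

Within the data shown here, two measured steps bear on this change. Pyridin-3-yl in place of 4-fluorophenyl on an amide-type nitrogen is a step that the two limits leave unreadable from compound 1 to compound 3 and adds no size. Methoxycarbonyl in place of fluoro on an aromatic carbon is an at least 1.1-fold lower number from compound 1 to compound 2 (0.07 log units; that floor lies within the scatter) and is the only step with a number at one end. Among the measured compounds shown here, with compound 2 at 21000 nM as the sole measured number, no large move is expected in this assay and at most a small drift toward lower numbers is anticipated. The expected step is an at least 1.4-fold lower number from compound 3 to compound 4 (0.16 log units; that floor lies within the scatter) and another reading at the limit remains quite possible. Compound 4 is estimated at 17000 nM with an expected range from 6000 nM to 30000 nM on this read-out.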

Compound 4, half-maximal effective concentration: > 25000 nM
Compound 4: no number, only a limit; the forecaster's own chance of this, stated with the estimate: 45%; at least 1.4-fold (0.16 log units) between middle value and limit.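

In this assay compound 4 gives > 25000 nM, a limit and not a number, with 4-aminophenyl on the amide-type nitrogen carrying 1 hydrogen-bond donor where pyridin-3-yl carries 0. Among these compounds, the steps among compound 1, compound 3 and compound 4 have limits at both ends and cannot be read, and the series gathers at a single limit: the limit of > 25000 nM in this assay, at which 3 of the 4 values shown sit. The only step here with a number at one end is an at least 1.1-fold higher number from compound 2 to compound 4 (0.07 log units; that floor lies within the scatter), for amino in place of methoxycarbonyl on an aromatic carbon, so this change gives no separation beyond the scatter.

The compounds shown leave open where the true values of compound 1, compound 3 and compound 4 lie beyond the limit. Also open, from the compounds shown here alone, is whether a carboxylic acid or an acetamido group on that aromatic carbon would give a number clearly apart from that of compound 2.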